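This account rests on a few compounds, and the source may have more. Where it says the series, first, only, none or still open, it means among the compounds named here.

Three compounds share one core and differ only in the group attached through the sulfur. Compound 1 `O=C(O)Cn1c(SCCOc2cccc3ccccc23)nc2ccccc21` carries the longest side chain, compound 2 `O=C(O)Cn1c(SCc2ccc(Cl)cc2)nc2ccccc21` a 4-chlorophenyl on the chain carbon, and compound 3 `COc1ccc(CSc2nc3ccccc3n2CC(=O)O)cc1` a 4-methoxyphenyl in that place. In an assay on HEK293 cells for displacement of a labelled ligand from prostaglandin D2 receptor 2 (Homo sapiens) (a higher number here means a weaker inhibitor, a lower number a stronger inhibitor), compound 1 gives 2000 nM, compound 2 gives 160 nM and compound 3 gives 210 nM. Compound 2 thus holds the lowest of the three numbers, although compound 3 sits within the scatter of it, and only compound 1 lies clearly apart.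

Compound 4 `Cc1ccccc1CSc1nc2ccccc2n1CC(=O)O` has not been measured. It differs from compound 2 by 2-methylphenyl in place of 4-chlorophenyl on a saturated chain carbon bound to a sulfur. Within the data shown here, the one measured step that touches this part of the molecule, a 1.3-fold higher number from compound 2 to compound 3 (0.12 log units; within the scatter), swapped one group on the ring for another and changed little. Among the measured compounds shown here, no measured step covers a methyl, nor a move of the substituent around the ring, so the expectation rests on the idea that a small change on this ring does little. Compound 4 is therefore expected to give 250 nM, within a range from 100 nM to 700 nM. That estimate means a step of a 1.6-fold higher number from compound 2 to compound 4 (0.19 log units; within the scatter), expected to stay within the scatter.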

Compound 4, half-maximal inhibitory concentration: 810 nM
For compound 4 the middle estimate is 3.2-fold (0.51 log units) below the measured one; measured number above the stated range.
By their numbers in this assay, from the lowest: compounds 2 and 3 (each within the scatter of the next); then compound 4; then compound 1.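

In this assay, 2-methylphenyl in place of 4-chlorophenyl on a saturated chain carbon bound to a sulfur gives a 5.1-fold higher number from compound 2 to compound 4 (0.70 log units; beyond the scatter), whereas methoxy in place of chloro gave only a 1.3-fold higher number from compound 2 to compound 3 (0.12 log units; within the scatter). A change to the aromatic ring at this place can therefore shift the number beyond the scatter, even though the group leaving and the group entering have the same heavy-atom count and neither has hydrogen-bond donors or acceptors. Nothing measured here gives a reason for this shift.

The step changes both the substituent and its place on the ring, and the compounds shown do not separate these two changes. Also open, from the compounds shown here alone, is how an unsubstituted phenyl, or a phenyl bearing an amine, would behave on the same chain carbon.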